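The source may hold more compounds than are shown below. What is called first, only, known or untested is meant among the compounds shown, and "the series" means these compounds.

Two compounds with a shared core carry a styryl arm and an amine on a ring, and both were tested in a functional assay on L02 cells (Homo sapiens) for inhibition, read by Griess assay, with stated times of 1 h and 24 h; on this read-out higher numbers stand for weaker inhibition and lower numbers for stronger inhibition. Compound 1, `COc1cc(/C=C/c2nc(Cl)cc(NC(C)C)n2)cc(OC)c1OC`, gives in this assay a value that is only a limit of the assay, < 40000 nM. Compound 2, `CC(C)Nc1nc(/C=C/c2ccccc2)nc2ccsc12`, likewise gives in this assay only a limit, > 1000000 nM. So compound 2 stands at the weak end of the numbers shown: its reading sits at the limit of > 1000000 nM in this assay, at which 1 of the 2 values shown sits, while the reading of compound 1 sits at the limit of < 40000 nM in this assay, at which 1 of the 2 values shown sits; no step between the two can be computed, since neither is a number.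

Compound 3, `COc1cccc(CNc2nc(/C=C/c3ccccc3)nc3ccsc23)c1`, is compound 2 with one change: 3-methoxybenzyl in place of isopropyl on a nitrogen on an aromatic ring. Among the compounds with values here, no measured pair shows what such a change does here, so the expectation rests on compound 2 alone. The step is expected to be small or none beyond the usual scatter, with a modest lean toward stronger inhibition, an at least 2.0-fold lower number from compound 2 to compound 3 (0.30 log units; that floor lies within the scatter). On that basis compound 3 is estimated to give in this assay about 500000 nM, somewhere between 50000 nM and 3000000 nM, with a good chance that only a limit is reported.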

Compound 3, half-maximal inhibitory concentration: > 1000000 nM
Compound 3: a limit, no number; the forecaster's own chance of this, stated with the estimate: 60%; at least 2.0-fold (0.30 log units) between middle value and limit.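

Compound 2 and compound 3 each give only a limit in this assay, not a number, and the step between them cannot be read. The compounds shown leave open whether 3-methoxybenzyl in place of isopropyl on a nitrogen on an aromatic ring changes inhibition at all, and if it does, in which direction and by how much.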